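A few compounds are considered here, and "the series" means these few. Any claim that something is new, unique, unknown or untested is made for them only; others in the source may bear on it.

Compound 1 `O=C(CCCCC(S)CCS)NO`, compound 2 `O=C(CCCCC(S)CCS)Nc1ccccc1` and compound 3 `O=C(CCCCC(S)CCS)Nc1ccccc1Cl` share one core and differ at one end of it. In a functional assay on HO8910 cells (Homo sapiens) for inhibition, read by MTT assay, with a stated time of 24 h, tested at 1 ug/mL (on this read-out lower numbers stand for less inhibition of growth and higher numbers for more inhibition of growth at the one concentration tested), compound 1 is recorded as "not active" (no number reported) with no number attached. Compound 2 gives 6.38% in this assay and compound 3 gives 7.72% in this assay as well. Among the measured compounds shown here, these are the only two numbers available, and they lie within the scatter of each other, so compound 2 holds no clear rank against compound 3.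

Compound 4 `O=C(CCCCC(S)CCS)Nc1ccc(OC(F)(F)F)cc1` differs from compound 2 in one place: trifluoromethoxy in place of hydrogen on an aromatic carbon, para to a large group (trifluoromethoxy in place of hydrogen on an aromatic carbon). For the measured compounds named here, only one measured step bears on this change, the exchange of chloro for hydrogen on an aromatic carbon, which amounts to a number 1.3 percentage points higher from compound 2 to compound 3 (within the scatter) and involves a different group, so it is a weak guide. With that single small step as the basis, little movement is expected in this assay and most likely none beyond the scatter, with a slight upward lean at most. The expected step is a number 2.6 percentage points higher from compound 2 to compound 4 (within the scatter) and it remains an estimate. For compound 4 the estimated value is 9% with an expected range from 3% to 20%.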

Compound 4, percent growth inhibition at one concentration: 0.56%
The estimate for compound 4 lay 8.4 percentage points above the measured number, outside the stated range (below it).
By their numbers in this assay, from the lowest: compounds 4, 2 and 3 (each within the scatter of the next).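

In this assay the exchange of hydrogen for trifluoromethoxy gives a number 5.8 percentage points lower from compound 2 to compound 4 (within the scatter) and so adds a second substitution on the aromatic ring of compound 2, alongside the chloro change, which gives a number 1.3 percentage points higher from compound 2 to compound 3 (within the scatter) and is also within the scatter. Until now only that single small atom had been placed on this ring, whereas this group brings 5 heavy atoms, without a ring and with no net charge, onto an aromatic carbon para to a large group, and even this larger change leaves the number within the scatter of that of compound 2. Nothing available explains this result or bears on any cause for it.

The compounds shown leave open whether a different kind of group at this place, such as an amine or a carboxylic acid, would shift the number beyond the scatter. They also leave open whether a longer chain between the amide and the aromatic ring, or a change at the two thiol groups of the shared core, would do so.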